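The source may report more compounds than this note shows. Statements on the series, on what has been measured and on what is new or still open speak of the compounds shown alone.

Measured so far:
compound 1, `Cc1cc(C)cc(SCc2ccc(/C=C/C(=O)Nc3ccccc3N)cc2)c1`: 46.1%
compound 2, `CC(C)(C)c1ccc(SCc2ccc(/C=C/C(=O)Nc3ccccc3N)cc2)cc1`: 71.5%
compound 3, `Nc1ccccc1NC(=O)/C=C/c1ccc(CSc2cccc3ccccc23)cc1`: 59.3%

In a functional assay on A549 cells (Homo sapiens) for inhibition, read by CCK-8 assay, with a stated time of 72 h, tested at 2 uM (a higher number here means more inhibition of growth at the concentration tested, a lower number less inhibition of growth), compound 3 gives 59.3%, the second highest of the three numbers. Its nearest neighbour is compound 2, and the gap is beyond the scatter: a number 12.2 percentage points lower from compound 2 to compound 3 (beyond the scatter). The furthest is compound 1, also beyond the scatter: a number 13.2 percentage points higher from compound 1 to compound 3 (beyond the scatter). The third measured step, a number 25.4 percentage points higher from compound 1 to compound 2 (beyond the scatter), spans the whole range seen so far. All three steps exchange one group on the sulfur for another and all three are modest.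

Compound 4 is `Nc1ccccc1NC(=O)/C=C/c1ccc(CSCCc2ccccc2)cc1`. It differs from compound 3 in one place: phenethyl in place of naphthalen-1-yl on a sulfur. Going by the values given here, no measured step introduces a phenethyl group, so the three aryl exchanges bear on it only by showing how much the group on the sulfur moves the numbers in this assay, namely by modest amounts between the bounds set by compound 1 and compound 2. Since compound 3 lies in the middle of that span with 59.3%, a modest step downward is expected, a number 9.3 percentage points lower from compound 3 to compound 4 (within the scatter), with the direction held loosely. Compound 4 is therefore estimated at 50% in this assay, within a range from 32% to 68%.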

Compound 4, percent growth inhibition at one concentration: 45.7%
Compound 4: middle estimate off by 4.3 percentage points, on the high side, and the stated range covers the measured number.
By their numbers in this assay, from the lowest: compounds 4 and 1 (each within the scatter of the next); then compound 3; then compound 2.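

In this assay, going by these compounds alone, phenethyl is the first group on the sulfur that carries its aromatic ring on a saturated chain, and it does not hold the level of the larger aryl groups: the change gives a number 13.6 percentage points lower from compound 3 to compound 4 (beyond the scatter), and against the 4-(tert-butyl)phenyl group it gives a number 25.8 percentage points lower from compound 2 to compound 4 (beyond the scatter), the latter as large as any step seen at this position. Against the 3,5-dimethylphenyl group the change gives a number 0.4 percentage points lower from compound 1 to compound 4 (within the scatter), so a saturated chain on the sulfur and a directly attached dimethylated phenyl ring cannot be told apart in this read-out, while the 4-(tert-butyl)phenyl and naphthalen-1-yl groups both stand clear of them. Nothing available accounts for these differences.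

The compounds shown leave open whether the outcome follows the chain itself, as a benzyl group or a longer chain ending in phenyl on the sulfur would test. They also leave open whether an amine or a carboxylic acid on the phenethyl ring would move the number in either direction.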